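A few compounds are considered here, and "the series" means these few. Any claim that something is new, unique, unknown or untested is made for them only; others in the source may bear on it.

Working notes on the series.

The shared core carries a substituent on a triple-bonded carbon. Compound 1 `CCCCCCC#Cc1cn(C/C=C/CN2C(=O)c3ccccc3C2=O)c(=O)[nH]c1=O` gives 28000 nM in a functional assay on CCRF-CEM cells (Homo sapiens) for antiproliferative activity, read by MTT assay, with a stated time of 3 days; on this read-out lower numbers stand for stronger inhibition and higher numbers for weaker inhibition. Compound 2 `CCCCCc1ccc(C#Cc2cn(C/C=C\CN3C(=O)c4ccccc4C3=O)c(=O)[nH]c2=O)cc1` gives 102000 nM in this assay. Compound 3 `CCCCCC#Cc1cn(C/C=C/CN2C(=O)c3ccccc3C2=O)c(=O)[nH]c1=O` is reported in this assay only as a limit of > 500000 nM, not as a number, so its standing on the numbers shown is known only as weaker than the scale reaches, consistent with the limit of > 500000 nM in this assay, at which 1 of the 3 values shown sits. Among the compounds with values here, the one measured step that touches compound 3 is an at least 17-fold higher number from compound 1 to compound 3 (1.25 log units; beyond the scatter), a shortening of the alkyl chain.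

Compound 4 `CCCCCc1ccc(C#Cc2cn(C/C=C/CN3C(=O)c4ccccc4C3=O)c(=O)[nH]c2=O)cc1` differs from compound 3 by 4-pentylphenyl in place of pentyl on a triple-bonded carbon. Within the data shown here, no measured step covers this exchange; compound 2 carries the same 4-pentylphenyl group on a differently arranged linker, and its value in this assay is the nearest guide. The expected step in this assay is an at least 7.1-fold lower number from compound 3 to compound 4 (0.85 log units; beyond the scatter), a move to a lower number, but the size is uncertain since compound 3 is a limit. The estimate for compound 4 in this assay is 70000 nM, with a range of 15000 nM to 350000 nM.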

Compound 4, half-maximal inhibitory concentration: 23000 nM
Estimate against measurement, compound 4: 3.0-fold (0.48 log units) above, within the range that was stated.
By their numbers in this assay, from the lowest: compounds 4 and 1 (each within the scatter of the next); then compound 2. At a limit, above all of these: compound 3.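

On this assay the triple-bonded carbon accepts an aromatic ring: 4-pentylphenyl in place of pentyl gives an at least 21-fold lower number from compound 3 to compound 4 (1.33 log units; beyond the scatter) and that size is only a bound, as the value of compound 3 is a limit: the limit of > 500000 nM in this assay, at which 1 of the 4 values shown sits. 4-pentylphenyl in place of hexyl gives a 1.2-fold lower number from compound 1 to compound 4 (0.09 log units; within the scatter) and so these values do not separate the ring-bearing group from the hexyl chain at this position. The double bond of the linker also matters for the 4-pentylphenyl pair, with a 4.4-fold lower number from compound 2 to compound 4 (0.65 log units; beyond the scatter) and the E form carrying the lower number: the fact that compounds 2 and 4 differ only in the configuration as drawn.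

From the compounds shown here alone, whether a plain phenyl, a longer chain such as octyl, or a terminal amine or carboxylic acid would hold or shift the number stays open. Also open, going by these compounds, is whether the same Z and E difference appears with hexyl on the triple-bonded carbon.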